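The compounds below may be only part of what the source reports. "The series", "measured", "known", "first", "only" and "open" are said of these compounds alone.

Compound 1 `CC1=C(C(=O)OCc2ccccc2)C(c2ccoc2)NC(=O)N1C`: 51%
Compound 2 `CC1=C(C(=O)OCC(C)C)C(c2cccs2)NC(=O)N1C`: 9%

In an assay on membranes from CHO cells for displacement of a labelled ligand from adenosine receptor A1 (Homo sapiens), read by scintillation counting, with a stated time of 60 min, tested at 1 uM (a higher number here means more inhibition at the concentration tested (going by the name of the read-out), a lower number less inhibition), compound 1 gives 51% and compound 2 gives 9%. Compound 2 stands lowest of the two numbers shown, and its nearest neighbour, compound 1, lies beyond the scatter above it. These two compounds differ in more than one place, so no single step between them is given; only their two values are shown. Compound 3 `CC1=C(C(=O)OCc2ccccc2)C(c2cccs2)NC(=O)N1C` has not yet been measured in this assay. It differs from compound 2 in one place: phenyl in place of isopropyl on a saturated chain carbon bound to an oxygen next to a carbonyl group. Compound 1 carries the benzyl ester as well and gives 51%, which is the only hint at direction. The step from compound 2 to compound 3 is therefore expected to be upward and beyond the scatter, roughly a number 31 percentage points higher from compound 2 to compound 3 (beyond the scatter). Compound 3 is expected to give about 40%, within a range from 15% to 65%.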

Compound 3, a percentage reported as inhibition, at one concentration (the size of the read-out at that concentration, not a potency): 50%
The estimate for compound 3 lay 10 percentage points below the measured number, and the stated range covers the measured number.
By their numbers in this assay, from the lowest: compound 2; then compounds 3 and 1 (each within the scatter of the next).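

In this assay, within the data shown here, the change from isopropyl to phenyl on a saturated chain carbon bound to an oxygen next to a carbonyl group gives a number 41 percentage points higher from compound 2 to compound 3 (beyond the scatter) with thiophen-2-yl held fixed, the first comparison in which this position alone changes. On the saturated ring carbon, thiophen-2-yl in place of furan-3-yl gives a number 1 percentage points lower from compound 1 to compound 3 (within the scatter) with the benzyl ester held fixed, so these two rings cannot be told apart in this pair. No measurement shown accounts for either step.

The compounds shown leave open whether the step needs an aromatic ring at this place, or whether a cyclohexyl group or a longer chain would serve as well. They also leave open what a methoxy group or an amine on the phenyl ring would do.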